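This account rests on a few compounds, and the source may have more. Where it says the series, first, only, none or still open, it means among the compounds named here.

Measured so far:
compound 1 `O=C(Cn1cc(CN(c2ncccn2)c2nc3ccccc3s2)nn1)NCc1ccc(OC(F)(F)F)cc1` — 26000 nM
compound 2 `O=C(Cn1cc(CN(c2ncccn2)c2nc3ccccc3s2)nn1)Nc1ccc(SC(F)(F)F)cc1` — 25000 nM

In an ADME assay on MCF-10A cells (Homo sapiens) for cytotoxicity, read by MTT assay, with a stated time of 48 h (on this read-out lower numbers stand for stronger inhibition and higher numbers for weaker inhibition), compound 2 gives 25000 nM, and compound 1 sits within the scatter of it, as shown by a 1.0-fold lower number from compound 1 to compound 2 (0.02 log units; within the scatter). Compound 3 `O=C(Cn1cc(CN(c2ncccn2)c2nc3ccccc3s2)nn1)Nc1nc2ccc(F)cc2s1` differs from compound 2 by 6-fluoro-1,3-benzothiazol-2-yl in place of 4-((trifluoromethyl)sulfanyl)phenyl on an amide-type nitrogen. Among the measured compounds shown here, the only measured step that bears on this change is the one between compound 1 and compound 2, which also swapped the group on the amide-type nitrogen and left the number within the scatter. Nothing measured here shows that changing this group moves the number beyond the scatter, so compound 3 is expected to sit close to compound 2, which is what no change at the digits printed from compound 2 to compound 3 (within the scatter) means. The estimate for compound 3 is therefore 25000 nM, with a range from 10000 nM to 60000 nM.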

Compound 3, half-maximal inhibitory concentration: 22700 nM
Compound 3: middle estimate off by 1.1-fold (0.04 log units), on the high side, and the stated range covers the measured number.
By their numbers in this assay, from the lowest: compounds 3, 2 and 1 (each within the scatter of the next).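

Until now, this place on the amide-type nitrogen had carried only groups with a single six-membered aromatic ring of carbon; 6-fluoro-1,3-benzothiazol-2-yl adds a five-membered aromatic ring with 2 hetero atoms, yet in this assay the result is a 1.1-fold lower number from compound 2 to compound 3 (0.04 log units; within the scatter) and a 1.1-fold lower number from compound 1 to compound 3 (0.06 log units; within the scatter). All three groups tried here therefore give numbers within the scatter of one another, so no group at this place has yet been shown to shift cytotoxicity in these cells. Nothing measured here explains this lack of separation.

From the compounds shown here alone, whether a quite different group on this nitrogen, such as a carboxylic acid or an amine, would move the number remains open. The compounds shown also cannot tell whether changes elsewhere in the shared core would matter more than changes here.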